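Triazole-linked series: cytotoxicity read-outs all at the limit

This account rests on a few compounds, and the source may have more. Where it says the series, first, only, none or still open, it means among the compounds named here.

Compound 1 `C=C1C[C@]23C[C@@]1(O)CC[C@@H]2c1cccc(C)c1[C@@H]3Cn1cc(-c2ccc(OC)cc2)nn1` carries a 4-methoxyphenyl on its triazole. In a functional assay on HL-60 cells (Homo sapiens) for cytotoxicity, read by MTT assay, with a stated time of 4 days (a higher number here means a weaker inhibitor, a lower number a stronger inhibitor), compound 1 gives > 20000 nM, which is a limit of the assay and not a number. Compound 3 `C=C1C[C@]23C[C@@]1(O)CC[C@@H]2c1cccc(C)c1[C@@H]3Cn1cc(-c2ccc(C)cc2)nn1` differs from compound 1 by methyl in place of methoxy on an aromatic carbon. In this assay compound 3 gives > 20000 nM, again a limit. The step that the two limits leave unreadable from compound 1 to compound 3 cannot be sized owing to the limit of > 20000 nM in this assay, at which 3 of the 3 values shown sit.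

Compound 2 `C=C1C[C@]23C[C@@]1(O)CC[C@H]2c1ccc(O)c(C)c1[C@@H]3Cn1cc(-c2ccc(OC)cc2)nn1` is built on a different core; the difference between the two cores is not broken down here. In this assay compound 2 gives > 20000 nM, once more a limit.

Compound 4 `C=C1C[C@]23C[C@@]1(O)CC[C@H]2c1ccc(O)c(C)c1[C@@H]3Cn1cc(-c2ccc(C)cc2)nn1` remains to be measured in this assay. It differs from compound 2 by methyl in place of methoxy on an aromatic carbon, the same change, at the same place, as that from compound 1 to compound 3. Nothing measured here separates methoxy from methyl on this aryl, and no value in the set has yet come below the limit.

The expected step for compound 4 is a step that the limit leaves unreadable from compound 2 to compound 4, which rests on the unreadable step that the two limits leave unreadable from compound 1 to compound 3 between the two measured partners of this change. The estimate for compound 4 in this assay is 30000 nM, with a plausible range from 12000 nM to 100000 nM, and the most likely outcome is that compound 4 is reported only as a limit.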

Compound 4, half-maximal inhibitory concentration: > 20000 nM
Compound 4 gave a limit, no number; the forecaster's own chance of this, stated with the estimate: 85%; the middle value is on the limit's open side.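

In this assay no step can be read between compound 2 and compound 4, since each gives only a limit and not a number, and the evidence is this: the limit of > 20000 nM in this assay, at which 4 of the 4 values shown sit.

The compounds shown leave open whether any member of this series, on either core, gives a value inside the range of the assay, and so whether 4-methoxyphenyl and 4-methylphenyl differ at all.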